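A Fluorine-for-Bromine Swap on the Triazole Benzyl Arm

A few compounds are considered here, and "the series" means these few. Any claim that something is new, unique, unknown or untested is made for them only; others in the source may bear on it.

Compound 3 `O=c1ccoc2cc(OCc3cn(Cc4ccc(Br)cc4)nn3)ccc12` is one of three compounds tested in a functional assay on MDA-MB-231 cells (Homo sapiens) for cytotoxicity, read by MTT assay, with a stated time of 48 h; a lower number here means a stronger inhibitor, a higher number a weaker inhibitor. In this assay compound 3 returns only a limit, > 100000 nM. Compound 1 `O=c1ccoc2cc(OCc3cn(Cc4ccccc4)nn3)ccc12` likewise gives a limit, > 100000 nM. Compound 2 `Cc1ccccc1Cn1cc(COc2ccc3c(=O)ccoc3c2)nn1` also gives a limit, > 100000 nM. The steps a step that the two limits leave unreadable from compound 1 to compound 3, a step that the two limits leave unreadable from compound 2 to compound 3 and a step that the two limits leave unreadable from compound 1 to compound 2 cannot be sized since (the limit of > 100000 nM in this assay, at which 3 of the 3 values shown sit). Compound 4 `O=c1ccoc2cc(OCc3cn(Cc4ccccc4F)nn3)ccc12` differs from compound 3 by 2-fluorophenyl in place of 4-bromophenyl on a saturated chain carbon bound to an aromatic nitrogen. Going by the values given here, with every measured step hidden behind the limit, no measured step bears on this change, and the expectation is that compound 4 stays at the limit as well. Compound 4 is therefore estimated at 150000 nM, within 30000 nM to 1000000 nM, the step that the limit leaves unreadable from compound 3 to compound 4 being expected to lie within the scatter.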

Compound 4, half-maximal inhibitory concentration: 29800 nM
For compound 4 the middle estimate is 5.0-fold (0.70 log units) above the measured one; the whole stated range lies above it.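

Going by these compounds alone, compound 4 is the first compound here to give a measured value in this assay, which shows that a change on this benzyl arm can move the read-out: an at least 3.3-fold lower number from compound 1 to compound 4 (0.52 log units; beyond the scatter), an at least 3.3-fold lower number from compound 2 to compound 4 (0.52 log units; beyond the scatter) and an at least 3.3-fold lower number from compound 3 to compound 4 (0.52 log units; beyond the scatter). Each step is only a minimum, and the other steps stay unreadable: the limit of > 100000 nM in this assay, at which 3 of the 4 values shown sit.

With fluoro seen only in 2-fluorophenyl, the compounds shown leave open whether 4-fluorophenyl would match compound 4. They also leave open whether chloro, methoxy or an amine on the same ring would give a lower number.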